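The source may hold more compounds than are shown below. What is called first, only, known or untested is meant among the compounds shown, and "the series" means these compounds.

Measured so far:
compound 1, `CC(C)(C)N(NC(=O)c1ccc(F)cc1)C(=O)c1ccccc1Cl`, 389 nM;
compound 2, `CC(C)(C)N(NC(=O)c1ccc(I)cc1)C(=O)c1ccccc1Cl`, 7.59 nM;
compound 3, `Cc1cccc(C(=O)NN(C(=O)c2ccccc2Cl)C(C)(C)C)c1C`, 20 nM.

In an assay on cells for agonist activity at ecdysone receptor (Bombyx mori), read by a luciferase reporter, with a stated time of 24 h (on this read-out lower numbers stand for an effect already at smaller amounts and higher numbers for an effect only at larger amounts of compound), compound 3 stands second highest of the three numbers. Its nearest neighbour is compound 2, the step being a 2.6-fold higher number from compound 2 to compound 3 (0.42 log units; beyond the scatter), and its furthest is compound 1, with a 19-fold lower number from compound 1 to compound 3 (1.29 log units; beyond the scatter). Compound 4 is `Cc1ccc(C(=O)NN(C(=O)c2ccccc2Cl)C(C)(C)C)cc1C`; it differs from compound 3 by 3,4-dimethylphenyl in place of 2,3-dimethylphenyl on a carbonyl carbon. The two measured steps that touch this aryl group, from compound 1 and from compound 2 to compound 3, each exchange the whole ring and were large and modest in turn, while a 51-fold lower number from compound 1 to compound 2 (1.71 log units; beyond the scatter) concerns only a halogen. For the measured compounds named here, no measured step moves a methyl group from one place on the ring to another, so nothing directly anchors this change. On that basis only a small step, if any beyond the scatter, is expected in this assay. Compound 4 is therefore estimated at 15 nM, within a range of 4 nM to 60 nM. This expectation amounts to a 1.3-fold lower number from compound 3 to compound 4 (0.12 log units; within the scatter).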

Compound 4, half-maximal effective concentration: 87.1 nM
For compound 4 the middle estimate is 5.8-fold (0.76 log units) below the measured one; the whole stated range lies below it.
By their numbers in this assay, from the lowest: compound 2; then compound 3; then compound 4; then compound 1.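

In this assay, rearranging the two methyl groups on the ring attached to the carbonyl carbon is enough to shift the result beyond the scatter, with a 4.4-fold higher number from compound 3 to compound 4 (0.64 log units; beyond the scatter), even though the group entering has the same atoms and counted features as the group leaving. The 3,4-dimethylphenyl compound takes an intermediate place among these compounds, with a 4.5-fold lower number from compound 1 to compound 4 (0.65 log units; beyond the scatter) and an 11-fold higher number from compound 2 to compound 4 (1.06 log units; beyond the scatter), so this aryl position responds to the arrangement of its methyl groups as well as to the identity of the whole group. No evidence is available to explain the shift between the two dimethylphenyl groups.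

The compounds shown leave open how a ring with a single methyl group would compare with either dimethylphenyl group. They also leave open whether a methoxy group or an amine in place of one methyl group would follow the same trend.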